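Amide in place of methoxy on the aryl ring of compound 1

The compounds below may be only part of what the source reports. "The series", "measured", "known", "first", "only" and "open" are said of these compounds alone.

Among the compounds with values here, compound 1 `COc1cccc(-c2cc(-c3ccc(C)o3)nc(N)n2)c1` gives 145 nM in an assay on membranes from brain (strain Sprague-Dawley) for displacement of a labelled ligand from adenosine receptor A1 (Rattus norvegicus), read by scintillation counting, with a stated time of 1 h (on this read-out lower numbers stand for stronger inhibition and higher numbers for weaker inhibition), the lowest of the two numbers measured so far. Compound 2 `COc1ccc(-c2cc(-c3ccc(C)o3)nc(N)n2)cc1OC` gives 650 nM in this assay; the step of a 4.5-fold higher number from compound 1 to compound 2 (0.65 log units; beyond the scatter) records that change. Compound 3 `Cc1ccc(-c2cc(-c3cccc(C(=O)N4CCCCC4)c3)nc(N)n2)o1` differs from compound 1 by (piperidin-1-yl)carbonyl in place of methoxy on an aromatic carbon. Within the data shown here, no measured step swaps the methoxy itself; the only measured step concerns a methoxy added elsewhere and moved the number modestly upward, so it bears only loosely on this change. For compound 3 a modest step upward is expected, a 2.8-fold higher number from compound 1 to compound 3 (0.44 log units; beyond the scatter). Compound 3 is estimated at 400 nM, with a range from 100 nM to 2000 nM.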

Compound 3, inhibition constant: 9.54 nM
Beside the measured number, compound 3's estimate is 42-fold (1.62 log units) above it; the whole stated range lies above it.
By their numbers in this assay, from the lowest: compound 3; then compound 1; then compound 2.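

Within the data shown here, replacing methoxy with (piperidin-1-yl)carbonyl on this aromatic carbon, meta to a large group, gives a 15-fold lower number from compound 1 to compound 3 (1.18 log units; beyond the scatter), the largest step so far and one towards stronger inhibition. This position therefore accepts a much larger group carrying a six-membered non-aromatic ring, with no loss of binding.

Still open, on these data alone, is whether the gain follows the carbonyl or the piperidine ring, a question that a dimethylamide, a piperidin-1-ylmethyl amine or a carboxylic acid on this carbon would address. Nothing available explains the size of this step.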